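The compounds below may be only part of what the source reports. "The series", "measured", "known", "first", "only" and "open" are said of these compounds alone.

The measured compounds and their values:

Compound 1, `CC(C)[C@@H]1CC[C@@H](C)C[C@@]12N(C)C(=O)[C@@H]1[C@H]3C(=O)N(c4ccccc4)C(=O)[C@H]3ON12`: 41%
Compound 2, `Cc1ccc(N2C(=O)[C@H]3[C@H](ON4[C@@H]3C(=O)N(C)[C@@]43C[C@H](C)CC[C@H]3C(C)C)C2=O)c(C)c1`: 79.4%

Within the data shown here, of the two numbers recorded in a functional assay, read by spectrophotometry, with a stated time of 2 h, tested at 2 mg/mL (a lower number here means a weaker effect, a higher number a stronger effect of the compound at the concentration tested), compound 2 gives the higher one, 79.4%, and its only neighbour is compound 1 with 41%. Among the measured compounds shown here, the single measured step is a number 38.4 percentage points higher from compound 1 to compound 2 (beyond the scatter), so the one change seen so far on this ring nitrogen moved the read-out well beyond the scatter and upward.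

Compound 3, `CC(C)[C@@H]1CC[C@@H](C)C[C@@]12N(C)C(=O)[C@@H]1[C@H]3C(=O)N(c4ccc5ccccc5c4)C(=O)[C@H]3ON12`, is the next member and differs from compound 2 by naphthalen-2-yl in place of 2,4-dimethylphenyl on an amide-type nitrogen in a ring. For the measured compounds named here, the step from compound 1 to compound 2 is the only one that bears on this exchange, and it does so only loosely: it shows that a larger group than phenyl on this nitrogen can raise the number, but no measured pair shows the move from 2,4-dimethylphenyl to naphthalen-2-yl itself. On that basis the expected step is a number 7.4 percentage points lower from compound 2 to compound 3 (within the scatter), a change not expected to exceed the scatter in either direction. Compound 3 is therefore estimated at 72%, with a range from 45% to 95%.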

Compound 3, a percentage reported as activity, at one concentration (the size of the read-out at that concentration, not a potency): 43.6%
Estimate against measurement, compound 3: 28.4 percentage points above, outside the stated range (below it).
By their numbers in this assay, from the lowest: compounds 1 and 3 (each within the scatter of the next); then compound 2.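

In this assay, naphthalen-2-yl in place of 2,4-dimethylphenyl on this amide-type nitrogen gives a number 35.8 percentage points lower from compound 2 to compound 3 (beyond the scatter), so the read-out at this position can fall as well as rise with the group placed there. Measured against the phenyl of compound 1, the same naphthalen-2-yl gives a number 2.6 percentage points higher from compound 1 to compound 3 (within the scatter), which means that this exchange produces no change that can be told from the scatter. Among these compounds, compound 2 alone stands clear of the others, and a higher heavy-atom count does not go with a higher number: compound 3, whose naphthalen-2-yl has 10 heavy atoms against 8 in the 2,4-dimethylphenyl, goes against any such pattern.

The data presented here offer nothing that explains why 2,4-dimethylphenyl stands apart from the other two groups. From the compounds shown here alone, it remains open whether one methyl group on the phenyl is enough to give part of the rise seen with compound 2, and how a benzyl group, a pyridinyl ring or a 4-methoxyphenyl group on this nitrogen would compare.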